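This account rests on a few compounds, and the source may have more. Where it says the series, first, only, none or still open, it means among the compounds named here.

Measured in a functional assay on MGC-803 cells (Homo sapiens) for inhibition, read by MTT assay, with a stated time of 72 h; a lower number here means a stronger inhibitor, a higher number a weaker inhibitor:
- compound 1 `FC(F)(F)c1ccc(CSc2nc(Sc3nncs3)cc(C(F)(F)F)n2)cc1`: 10900 nM
- compound 2 `Cc1nnc(Sc2cc(C(F)(F)F)nc(SCc3ccc(C(F)(F)F)cc3)n2)s1`: 11400 nM
- compound 3 `FC(F)(F)c1ccc(CSc2nc(SC3=NCCS3)cc(C(F)(F)F)n2)cc1`: 24500 nM

Of the three, compound 3 gives the highest number, 24500 nM. Next in this assay is compound 4 `FC(F)(F)c1ccc(CSc2nc(Sc3ncc(-c4ccncc4)s3)cc(C(F)(F)F)n2)cc1`, with a group of 11 heavy atoms (8 carbon, 2 nitrogen, 1 sulfur; one five-membered aromatic ring with 2 hetero atoms, one six-membered aromatic ring with 1 hetero atom) in place of a group of 5 heavy atoms (3 carbon, 1 nitrogen, 1 sulfur; one five-membered non-aromatic ring with 2 hetero atoms), on a sulfur.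

Within the data shown here, two measured steps bear on this change at the same place: a 2.2-fold higher number from compound 1 to compound 3 (0.35 log units; beyond the scatter) and a 2.1-fold higher number from compound 2 to compound 3 (0.33 log units; beyond the scatter). Both are modest and lead away from a five-membered aromatic ring, so returning to such a ring should lower the number. a 1.0-fold higher number from compound 1 to compound 2 (0.02 log units; within the scatter) shows that a methyl on that ring changes little. Among the measured compounds shown here, no measured compound carries a pyridin-4-yl group, so its contribution is unknown. The expected step is modest, a 2.5-fold lower number from compound 3 to compound 4 (0.39 log units; beyond the scatter). For compound 4 the estimated value is 10000 nM, with an expected range of 3500 nM to 25000 nM.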

Compound 4, half-maximal inhibitory concentration: 5770 nM
Compound 4: the middle estimate sits 1.7-fold (0.24 log units) above what was measured, and the stated range covers the measured number.
By their numbers in this assay, from the lowest: compounds 4, 1 and 2 (each within the scatter of the next); then compound 3.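

On the sulfur, the two-ring group 5-(pyridin-4-yl)-1,3-thiazol-2-yl is accepted in this assay, and the non-aromatic ring is the outlier, with a 4.2-fold lower number from compound 3 to compound 4 (0.63 log units; beyond the scatter). Against the 1,3,4-thiadiazol-2-yl and 5-methyl-1,3,4-thiadiazol-2-yl groups, the larger group gives a 1.9-fold lower number from compound 1 to compound 4 (0.28 log units; within the scatter) and a 2.0-fold lower number from compound 2 to compound 4 (0.30 log units; within the scatter), so added size at this place separates nothing from those two. No measurement at hand explains these differences. From the compounds shown here alone, what a phenyl group, an amine or a carboxylic acid in place of the pyridin-4-yl group would give stays open.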